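Stilbene-type replacement of the 4-fluorophenyl in the indole series

The compounds below may be only part of what the source reports. "The series", "measured", "known", "first", "only" and "open" are said of these compounds alone.

Measured so far in a functional assay on MCF7 cells (Homo sapiens) for cytotoxicity, read by MTT assay, with a stated time of 2 days, tested at 10 uM; on this read-out higher numbers stand for a weaker effect at the one concentration tested and lower numbers for a stronger effect:
compound 1 `CC(=O)c1cc(-c2ccc(F)cc2)cc2cc(-c3ccccc3)[nH]c12`: 73.8%
compound 2 `CC(=O)c1cc(-c2ccc(F)cc2)cc2cc(-c3ccc(F)cc3)[nH]c12`: 90.6%
compound 3 `COc1ccc(-c2cc3cc(-c4ccc(F)cc4)cc(C(C)=O)c3[nH]2)cc1`: 77.5%

Compound 2 stands highest of the three numbers in this assay, that is, with the weakest effect at the single concentration; the nearest is compound 3, lower by a number 13.1 percentage points lower from compound 2 to compound 3 (beyond the scatter), and the furthest is compound 1, from which the step of a number 16.8 percentage points higher from compound 1 to compound 2 (beyond the scatter) runs. Both steps lie beyond the scatter, while a number 3.7 percentage points higher from compound 1 to compound 3 (within the scatter) lies within it.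

Compound 4 `CC(=O)c1cc(/C=C/c2ccccc2)cc2cc(-c3ccc(F)cc3)[nH]c12` is not yet measured. It differs from compound 2 by 2-phenylethenyl in place of 4-fluorophenyl on an aromatic carbon. The measured steps change a different group of the shared core, so none of them bears directly on this change. What they do show is that in both cases where a fluoro group is present the number is higher, and where it is absent or replaced the number is lower, as in a number 13.1 percentage points lower from compound 2 to compound 3 (beyond the scatter). Removing the fluorine here and adding a double bond outside the aromatic rings is therefore expected to give a modest step downward in this assay, on the order of those seen, though with wide uncertainty given that the altered group is different. Compound 4 is expected to give about 76%, within a range of 55% to 95%, a step of a number 14.6 percentage points lower from compound 2 to compound 4 (beyond the scatter) from compound 2.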

Compound 4, a percentage reported as activity, at one concentration (the size of the read-out at that concentration, not a potency): 69.5%
Compound 4: middle estimate off by 6.5 percentage points, on the high side; the range from low to high includes it.
By their numbers in this assay, from the lowest: compounds 4, 1 and 3 (each within the scatter of the next); then compound 2.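

For the compounds shown here, this is the first change at this position, the aromatic carbon meta to the acetyl group and para to a fused ring; the earlier steps all altered the aryl group elsewhere on the shared core. In this assay, 2-phenylethenyl in place of 4-fluorophenyl gives a number 21.1 percentage points lower from compound 2 to compound 4 (beyond the scatter), so the position does not require a directly attached aryl ring, and the longer group with its double bond outside the aromatic rings goes with a stronger effect at the one concentration tested. No measurement here explains this step.

On these data alone, the replacement removes the fluorine and inserts the double bond in one move, so the share of each in the step stays open; 4-fluorostyryl, with the fluorine kept on the longer group, or an unsubstituted phenyl at this position would separate the two, and 2-phenylethyl would test the double bond itself. Also open, as far as these compounds go, is whether a polar group such as an amine or a carboxylic acid is accepted here, and since the read-out is a single-concentration figure, the step says nothing about potency.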